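The compounds below may be only part of what the source reports. "The series", "measured", "known", "first", "only" and "open" are said of these compounds alone.

Compound 1 `CC(C)Cn1nc(C(=O)N[C@H]2COc3ccccc3N(C)C2=S)nc1Cc1ccccc1` gives 1230 nM in a functional assay on HT-29 cells (Homo sapiens) for inhibition, read by luminescence and CellTiter-Glo, with a stated time of 24 h; a lower number here means that less compound is needed, a higher number that more compound is needed for the effect. Compound 2 `CN1C(=S)[C@@H](NC(=O)c2nc(Cc3ccccc3)n(CCCC(F)(F)F)n2)COc2ccccc21` gives 2380 nM.

Where compound 2 stands among these two numbers is told by a 1.9-fold higher number from compound 1 to compound 2 (0.29 log units; within the scatter): that gap lies within the scatter, so the two compounds cannot be told apart on potency. Compound 3 `CN1C(=S)[C@@H](NC(=O)c2nc(Cc3ccccc3)n(CC3CCOC3)n2)COc2ccccc21` has not been measured. It differs from compound 2 at a single place: oxolan-3-yl in place of 3,3,3-trifluoropropyl on a saturated chain carbon bound to an aromatic nitrogen. Within the data shown here, only one measured step touches that place, a 1.9-fold higher number from compound 1 to compound 2 (0.29 log units; within the scatter), and it stayed within the scatter although it exchanged one chain for another there. Among the measured compounds shown here, no measured compound carries a ring at that place, so what the entering group does is untested. The expected step from compound 2 is therefore small, a 1.2-fold lower number from compound 2 to compound 3 (0.08 log units; within the scatter), nothing beyond the scatter. On that basis compound 3 is expected to give 2000 nM in this assay, with a range from 700 nM to 6000 nM.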

Compound 3, half-maximal effective concentration: 4420 nM
Beside the measured number, compound 3's estimate is 2.2-fold (0.34 log units) below it; the range from low to high includes it.
By their numbers in this assay, from the lowest: compounds 1, 2 and 3 (each within the scatter of the next, the first and the last beyond it).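

Oxolan-3-yl is the first ring at this place, on a saturated chain carbon bound to an aromatic nitrogen, and in this assay it cannot be told apart from the 3,3,3-trifluoropropyl chain (a 1.9-fold higher number from compound 2 to compound 3 (0.27 log units; within the scatter)). Set against the isopropyl group, the same ring gives the first step here that passes the scatter (a 3.6-fold higher number from compound 1 to compound 3 (0.56 log units; beyond the scatter)), though only a modest one, so the number does respond to the group at this place. No measurement is available that would explain this step.

On these data alone, what a plain cyclopentyl ring would give in place of oxolan-3-yl stays open, and that comparison would separate the effect of the ring from that of its oxygen. Also open, as far as these compounds go, is how the number would respond to an amine or a carboxylic acid at this place.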